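Compound 4: a Nitrogen Returns to the Carbonyl Carbon

The source may report more compounds than this note shows. Statements on the series, on what has been measured and on what is new or still open speak of the compounds shown alone.

In an assay on HL-60 cells for agonist activity at vitamin D3 receptor (Homo sapiens), read by microscopy, with a stated time of 96 h (on this read-out lower numbers stand for an effect already at smaller amounts and higher numbers for an effect only at larger amounts of compound), compound 3 `CCn1c(C(=O)OC(C)CCO)ccc1C(CC)(CC)c1ccc(OCC(=O)C(C)(C)C)c(C)c1` gives 380 nM, the highest number among the three measured compounds. Compound 1 `CCn1c(C(=O)NCCN(C)C)ccc1C(CC)(CC)c1ccc(OCC(=O)C(C)(C)C)c(C)c1` gives 77 nM and compound 2 `CCn1c(C(=O)NCCN)ccc1C(CC)(CC)c1ccc(OCC(=O)C(C)(C)C)c(C)c1` gives 120 nM; between them a 1.6-fold higher number from compound 1 to compound 2 (0.19 log units; within the scatter). Compound 4 `CCOc1ccc(NC(=O)c2ccc(C(CC)(CC)c3ccc(OCC(=O)C(C)(C)C)c(C)c3)n2CC)cc1` differs from compound 3 by a group of 10 heavy atoms (8 carbon, 1 nitrogen, 1 oxygen; one six-membered aromatic ring of carbon only) in place of a group of 6 heavy atoms (4 carbon, 2 oxygen; no ring), on a carbonyl carbon. Within the data shown here, the steps that bear on this change sit on the same carbonyl carbon: a 4.9-fold higher number from compound 1 to compound 3 (0.69 log units; beyond the scatter) and a 3.2-fold higher number from compound 2 to compound 3 (0.50 log units; beyond the scatter), each moving from a nitrogen-containing group to an oxygen-containing one. Read in reverse, restoring a nitrogen at that position is expected to give compound 4 a lower number in this assay, a 3.5-fold lower number from compound 3 to compound 4 (0.54 log units; beyond the scatter), although the entering group carries no amino chain as compounds 1 and 2 do. Compound 4 is therefore estimated at 110 nM, with a range from 35 nM to 350 nM.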

Compound 4, half-maximal effective concentration: > 50000 nM
Compound 4 ended at the assay's limit; the forecaster's own chance of this, stated with the estimate: 5%; middle value at least 450-fold (2.65 log units) from the limit.
By their numbers in this assay, from the lowest: compounds 1 and 2 (each within the scatter of the next); then compound 3. At a limit, above all of these: compound 4.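

The reading of compound 4 is a limit of the assay, not a number: the limit of > 50000 nM in this assay, at which 1 of the 4 values shown sits. At this carbonyl carbon a nitrogen alone does not keep the number low: with 4-ethoxyphenyl on the amide-type nitrogen, the change gives an at least 640-fold higher number from compound 1 to compound 4 (2.81 log units; beyond the scatter) and an at least 410-fold higher number from compound 2 to compound 4 (2.61 log units; beyond the scatter). The group without nitrogen also stands ahead, with an at least 130-fold higher number from compound 3 to compound 4 (2.11 log units; beyond the scatter), so the earlier order does not hold for this entering group. Going by these compounds, whether the step goes with the aromatic ring, the ethoxy group or the missing amine stays open. On these data alone, how an unsubstituted phenyl or an aminomethylphenyl on that nitrogen would read also stays open.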